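Chloro in Place of Methyl: Expectation for Compound 3

A few compounds are considered here, and "the series" means these few. Any claim that something is new, unique, unknown or untested is made for them only; others in the source may bear on it.

Compound 2 `COc1ccc(CNC(=O)/C(C#N)=C/c2ccc(C)cc2)cc1` gives 41000 nM in a functional assay on NCI-H460 cells (Homo sapiens) for inhibition, read by MTT assay, with a stated time of 72 h (on this read-out lower numbers stand for stronger inhibition of growth and higher numbers for weaker inhibition of growth), and is the only plain number shown. Compound 1 `COc1ccc(CNC(=O)/C(C#N)=C/c2ccc[nH]2)cc1` is reported in this assay only as the limit > 50000 nM. The step of an at least 1.2-fold lower number from compound 1 to compound 2 (0.08 log units; that floor lies within the scatter) rests on the floor the limit of > 50000 nM in this assay, at which 1 of the 2 values shown sits, and lies within the scatter. Compound 3 `COc1ccc(CNC(=O)/C(C#N)=C/c2ccc(Cl)cc2)cc1` differs from compound 2 by chloro in place of methyl on an aromatic carbon. No measured step bears directly on this change, and the single step shown is within the scatter, so the change in this assay is expected to stay within the scatter, a step of a 1.4-fold lower number from compound 2 to compound 3 (0.14 log units; within the scatter). Compound 3 is therefore estimated at 30000 nM, with a range from 10000 nM to 90000 nM.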

Compound 3, concentration for 50% growth inhibition: 14000 nM
Compound 3: the middle estimate sits 2.1-fold (0.33 log units) above what was measured; the range from low to high includes it.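

In this assay the exchange of methyl for chloro, para to a large group, gives a 2.9-fold lower number from compound 2 to compound 3 (0.47 log units; beyond the scatter) and so shows that this aromatic carbon responds to a change of a single heavy atom. Within the data shown here, the step of an at least 3.5-fold lower number from compound 1 to compound 3 (0.55 log units; beyond the scatter) is the first from compound 1 to pass beyond the scatter. It is only a floor, resting on the limit reported for compound 1: the limit of > 50000 nM in this assay, at which 1 of the 3 values shown sits. Still open, as far as these compounds go, is how fluoro, trifluoromethyl, an amine or a carboxylic acid would read on this carbon, and whether chloro elsewhere on the ring gives a similar step.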